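The source may hold more compounds than are shown below. What is called first, only, known or untested is meant among the compounds shown, and "the series" means these compounds.

Measured so far:
compound 1, `CS(=O)(=O)c1cnc(C(=O)CCc2ccc(-c3ccccc3)cc2)o1`, 1.2 nM
compound 2, `COC(=O)c1cccc(-c2cnc(C(=O)CCc3ccc(-c4ccc(CN5CCCCC5)cc4)cc3)o2)n1`, 9 nM
compound 3, `CNC(=O)c1cnc(C(=O)CCc2ccc(COc3ccccc3)cc2)o1`, 3.6 nM

All three were tested in an assay for inhibition of Fatty-acid amide hydrolase 1 (Rattus norvegicus); on this read-out lower numbers stand for stronger inhibition and higher numbers for weaker inhibition. Compound 1 stands lowest of the three numbers, which on this read-out means the strongest inhibition of the set. Compound 3 comes nearest to it, and that gap already lies beyond the usual scatter of repeated measurements; compound 2 lies furthest away, also beyond the scatter.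

Compound 4, `O=C(CCc1ccc(-c2ccccc2)cc1)c1ncc(-c2cccnc2)o1`, has not yet been measured. It differs from compound 1 in a single place: pyridin-3-yl in place of methylsulfonyl on an aromatic carbon. The remainder of the molecule is unchanged.

Within the data shown here, no measured pair shows this particular exchange, so its effect must be judged from the compounds at hand. Compound 3, which carries a different group on the shared core, gives 3.6 nM in this assay; compound 2, which differs on the core and in its chain as well, gives 9 nM. Both stay at low numbers while sitting above compound 1. On that basis the step from compound 1 to compound 4 is expected to be a 6.7-fold higher number from compound 1 to compound 4 (0.82 log units; beyond the scatter), a modest weakening beyond the scatter. Compound 4 is therefore estimated at about 8 nM, within 2 nM to 30 nM.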

Compound 4, inhibition constant: 1.1 nM
Compound 4: middle estimate off by 7.3-fold (0.86 log units), on the high side; the measured number lies below the stated range.
By their numbers in this assay, from the lowest: compounds 4 and 1 (each within the scatter of the next); then compound 3; then compound 2.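

In this assay, replacing methylsulfonyl with pyridin-3-yl gives a 1.1-fold lower number from compound 1 to compound 4 (0.04 log units; within the scatter), so the two groups cannot be told apart by this measurement. Among these compounds, this is the first exchange at this aromatic carbon, next to the ring oxygen, that can be read on its own. The rest of the molecule stays fixed, whereas compound 2 and compound 3 differ from compound 1 in more than one place. It shows that this position tolerates a sulfur-containing group with no ring being replaced by a larger six-membered aromatic ring, with no measurable loss of inhibition, although nothing available here explains why the two groups perform alike.

From the compounds shown here alone, it remains open whether this tolerance extends to quite different groups at the same carbon, such as a carboxylic acid, an amine or a plain phenyl ring, the last of which would show whether the ring nitrogen of pyridin-3-yl matters at all. Going by these compounds, it is also open whether the same exchange would leave the number unchanged on a molecule with a different chain, such as that of compound 3.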